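Replacing 4-methylphenyl with 4-chloropyridin-2-yl in the series

The source may report more compounds than this note shows. Statements on the series, on what has been measured and on what is new or still open speak of the compounds shown alone.

Measured in an ADME assay on L02 cells (Homo sapiens) for inhibition, read by CCK-8 assay, with a stated time of 48 h; on this read-out lower numbers stand for stronger inhibition of growth and higher numbers for weaker inhibition of growth:
Compound 1 `Cc1ccccc1Nc1nc(Nc2cccnc2)ncc1Cl`: 22900 nM
Compound 2 `Cc1ccccc1Nc1nc(Nc2ccccc2)ncc1Cl`: > 100000 nM (a limit)
Compound 3 `Cc1ccc(Nc2ncc(Cl)c(Nc3ccccc3C)n2)cc1`: > 100000 nM (a limit)

Compound 3 stands at > 100000 nM, which is a limit of this assay and not a number. Compound 3 thus sits at the limit of > 100000 nM in this assay, at which 2 of the 3 values shown sit.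

Compound 4 `Cc1ccccc1Nc1nc(Nc2cc(Cl)ccn2)ncc1Cl` carries 4-chloropyridin-2-yl in place of 4-methylphenyl on a nitrogen on an aromatic ring.

The closest measured step is an at least 4.3-fold higher number from compound 1 to compound 3 (0.64 log units; beyond the scatter), which exchanges pyridin-3-yl for the same 4-methylphenyl. The step of an at least 4.3-fold higher number from compound 1 to compound 2 (0.64 log units; beyond the scatter), with phenyl in place of pyridin-3-yl, runs the same way. Both are beyond the scatter, and both are bounded on one side only. The remaining step, a step that the two limits leave unreadable from compound 2 to compound 3, gives no size.

Read in reverse, these steps suggest that a ring with a hetero atom in place of one of carbon only should bring the number down in this assay. For the measured compounds named here, the expectation rests on compound 1 at 22900 nM, the only number. Going by the values given here, no measured compound carries 4-chloropyridin-2-yl, so the range stays wide, and a result at the limit remains possible.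

The expected change is an at least 2.8-fold lower number from compound 3 to compound 4 (0.45 log units; beyond the scatter).

For compound 4 the estimate is 35000 nM, with an expected range from 12000 nM to 100000 nM.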

Compound 4, concentration for 50% growth inhibition: 41500 nM
Compound 4: the middle estimate sits 1.2-fold (0.07 log units) below what was measured; low and high end bracket the measured number.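

Working notes: in this assay, a ring with a hetero atom at this place on a nitrogen on an aromatic ring gives a readable number for the second time, with an at least 2.4-fold lower number from compound 3 to compound 4 (0.38 log units; beyond the scatter) and an at least 2.4-fold lower number from compound 2 to compound 4 (0.38 log units; beyond the scatter). Across the four compounds, both rings with a hetero atom read below the limit and both rings of carbon only sit at it, with no compound against this pattern. 4-Chloropyridin-2-yl and pyridin-3-yl cannot be told apart here, with a 1.8-fold higher number from compound 1 to compound 4 (0.26 log units; within the scatter), so neither the chlorine nor the different ring attachment shows a separate effect at this resolution, and compound 2 and compound 3 hold limits of the assay, not numbers, which leaves both lower steps bounded on one side only: the limit of > 100000 nM in this assay, at which 2 of the 4 values shown sit.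

Still open, from the compounds shown here alone, is how pyridin-2-yl without the chlorine would read, which would separate the ring from its chlorine in this assay. Also open, going by these compounds, is whether a ring of carbon only carrying an amine or a carboxylic acid would leave the limit as well, or whether the hetero atom must sit in the ring itself.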